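Notes on the step to the ethylsulfonyl compound 4

A few compounds are considered here, and "the series" means these few. Any claim that something is new, unique, unknown or untested is made for them only; others in the source may bear on it.

Measured in a functional assay on the whole organism for antagonist activity, with Mus musculus as the target; on this read-out higher numbers stand for an effect only at larger amounts of compound and lower numbers for an effect already at smaller amounts:
- compound 1 `Cn1c(-c2ccccc2)nnc1[S+](C)[O-]`: 18.6 mg/kg
- compound 2 `COc1ccc(-c2nnc(S(C)(=O)=O)n2C)cc1`: > 200 mg/kg (a limit, not a number)
- compound 3 `Cn1c(-c2ccccc2F)nnc1[S+](C)[O-]`: 20 mg/kg

Not yet measured: compound 4 `CCS(=O)(=O)c1nnc(-c2ccccc2F)n1C`.

Compound 3 gives 20 mg/kg and cannot be told apart from compound 1, the step being a 1.1-fold higher number from compound 1 to compound 3 (0.03 log units; within the scatter). Compound 2 gives > 200 mg/kg, which is a limit and not a number.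

The change under study is a group of 5 heavy atoms (2 carbon, 2 oxygen, 1 sulfur; no ring) in place of a group of 3 heavy atoms (1 carbon, 1 oxygen, 1 sulfur; no ring), on an aromatic carbon. Ethylsulfonyl enters on an aromatic carbon, between two ring nitrogen atoms, and the fluoro of compound 3 stays in place. Going by the values given here, no measured step covers this change. Among the compounds with values here, the single measured step concerns the fluoro alone and says nothing about the new group. Within the data shown here, compound 2 is the only measured compound with a sulfonyl group, but it differs from compound 3 in more than that group, so it is weak guidance. On the strength of the limit of compound 2, > 200 mg/kg, a move towards a higher number is expected in this assay, of uncertain size.

The expected step is a 2.3-fold higher number from compound 3 to compound 4 (0.35 log units; beyond the scatter). For compound 4 the estimate is 45 mg/kg, with an expected range from 8 mg/kg to 200 mg/kg.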

Compound 4, dose for half-maximal effect: 85.8 mg/kg
For compound 4 the middle estimate is 1.9-fold (0.28 log units) below the measured one; the range from low to high includes it.
By their numbers in this assay, from the lowest: compounds 1 and 3 (each within the scatter of the next); then compound 4. At a limit, above all of these: compound 2.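

In this assay, the aromatic carbon between two ring nitrogen atoms proves sensitive to the group it carries: with the fluoro kept in place, ethylsulfonyl gives a 4.3-fold higher number from compound 3 to compound 4 (0.63 log units; beyond the scatter). Going by these compounds alone, the only earlier step, a 1.1-fold higher number from compound 1 to compound 3 (0.03 log units; within the scatter), concerned the fluoro alone, so this is the first reading on the series that a change at this carbon moves the number beyond the scatter, and the move is towards an effect only at larger amounts of compound. Compound 4 carries a sulfonyl group and still gives a number, while compound 2, which also carries a sulfonyl group but differs in more than one place, stands at a limit, not a number: the limit of > 200 mg/kg in this assay, at which 1 of the 4 values shown sits.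

Going by these compounds, the step brings in an extra oxygen and an extra carbon at once, so the share of each in the change stays open, and a methylsulfonyl group on the core of compound 3 would separate them. Also open, on these data alone, is how this carbon responds to a longer chain such as propylsulfonyl or to a group without sulfur such as an amine, and whether any group here gives a lower number than compound 3.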